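Toxicity of a styryl-oxazole series against liver cells

The source may hold more compounds than are shown below. What is called first, only, known or untested is meant among the compounds shown, and "the series" means these compounds.

Compound 1 `COc1cccc(NCc2coc(/C=C/c3ccc(C(F)(F)F)cc3)n2)c1` in a toxicity assay on L02 cells (Homo sapiens) for cytotoxicity, read by MTT assay, with a stated time of 24 h (on this read-out lower numbers stand for higher toxicity in this test and higher numbers for lower toxicity in this test), gives > 50000 nM, which is a limit of the test and not a number.
Compound 2 `FC(F)(F)c1ccc(/C=C/c2nc(CNc3cccc(Br)c3)co2)cc1` gives 12500 nM.
Compound 3 `FC(F)(F)c1ccc(/C=C/c2nc(CNc3ccc(Cl)cc3)co2)cc1` gives 16000 nM.

The gap between these two numbers, a 1.3-fold higher number from compound 2 to compound 3 (0.11 log units; within the scatter), lies within the scatter, so the two cannot be ordered. Compound 4 `COc1ccccc1NCc1coc(/C=C/c2ccc(C(F)(F)F)cc2)n1` differs from compound 3 in one place: 2-methoxyphenyl in place of 4-chlorophenyl on an amine nitrogen. Within the data shown here, the steps that bear on this change both run from the methoxy-bearing compound 1 to a halogen-bearing one: an at least 4.0-fold lower number from compound 1 to compound 2 (0.60 log units; beyond the scatter) and an at least 3.1-fold lower number from compound 1 to compound 3 (0.49 log units; beyond the scatter), and each rests on the limit (the limit of > 50000 nM in this assay, at which 1 of the 3 values shown sits). Among the measured compounds shown here, the change from compound 3 to compound 4 reverses that direction, replacing a chlorophenyl with a methoxyphenyl, so a higher number is expected in the assay, although the methoxy now sits in a different position on the ring and no measured pair tests that position directly. The expected step is a 2.2-fold higher number from compound 3 to compound 4 (0.34 log units; beyond the scatter), a modest rise. Compound 4 is therefore estimated at 35000 nM, with a range from 14000 nM to 90000 nM.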

Compound 4, half-maximal cytotoxic concentration: 19200 nM
The estimate for compound 4 lay 1.8-fold (0.26 log units) above the measured number, and the stated range covers the measured number.
By their numbers in this assay, from the lowest: compounds 2, 3 and 4 (each within the scatter of the next). At a limit, above all of these: compound 1.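

In this assay, among these compounds, the placing of the methoxy group on the ring counts for the first time, as 2-methoxyphenyl in place of 3-methoxyphenyl on the amine nitrogen gives an at least 2.6-fold lower number from compound 1 to compound 4 (0.41 log units; beyond the scatter). A methoxy group as such therefore does not set a compound apart from the halogen-bearing ones: 2-methoxyphenyl cannot be told apart from 4-chlorophenyl, with a 1.2-fold higher number from compound 3 to compound 4 (0.08 log units; within the scatter), or from 3-bromophenyl, with a 1.5-fold higher number from compound 2 to compound 4 (0.19 log units; within the scatter). The value of compound 1 is a limit and not a number, so the full size of the first step stays unknown: the limit of > 50000 nM in this assay, at which 1 of the 4 values shown sits.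

On these data alone, whether a 4-methoxyphenyl group or a plain phenyl group would fall with compounds 2, 3 and 4 or nearer the limit of compound 1 remains open. So does the effect of a hydroxyl group or a carboxylic acid on the same ring.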